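Bromophenyl Analogue of a Chalcone Amide: Expected Cytotoxicity

The compounds below may be only part of what the source reports. "The series", "measured", "known", "first", "only" and "open" are said of these compounds alone.

Measured compounds:
Compound 1 `COC(=O)c1cc(-c2cccc(NC(=O)c3ccc(/C=C/C(=O)c4cccc(F)c4)cc3)c2)on1`: in an ADME assay on Vero cells (Chlorocebus sabaeus) for cytotoxicity, read by MTT assay, with a stated time of 72 h (on this read-out lower numbers stand for higher toxicity in this test and higher numbers for lower toxicity in this test), compound 1 gives a limit of > 40 ug/mL.
Compound 2 `COC(=O)c1cc(-c2cccc(NC(=O)c3ccc(/C=C/C(=O)c4cc(F)ccc4F)cc3)c2)on1`: in this assay compound 2 gives a limit of > 40 ug/mL.
Compound 3 `CCCOc1ccc(C(=O)/C=C/c2ccc(C(=O)Nc3cccc(-c4cc(C(=O)OC)no4)c3)cc2)cc1`: in this assay compound 3 gives a limit of > 40 ug/mL.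

Compound 2 stands at the limit of this assay, and it is not alone there: the limit of > 40 ug/mL in this assay, at which 3 of the 3 values shown sit. Because all three results are limits rather than numbers, the three steps among them cannot be read: a step that the two limits leave unreadable from compound 1 to compound 2, a step that the two limits leave unreadable from compound 1 to compound 3 and a step that the two limits leave unreadable from compound 2 to compound 3. Nothing in these data separates one compound from another in this assay.

Compound 4 `COC(=O)c1cc(-c2cccc(NC(=O)c3ccc(/C=C/C(=O)c4cccc(Br)c4)cc3)c2)on1` is the next compound to be tested. It differs from compound 2 in one place: 3-bromophenyl in place of 2,5-difluorophenyl on a carbonyl carbon. For the measured compounds named here, the only steps that bear on this change are the unreadable ones above, so they give no direction and no size. Going by the values given here, the sole pattern that can be drawn is that every compound so far sits at the limit.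

On that basis compound 4 is expected to give 60 ug/mL in this assay, within a range of 30 ug/mL to 120 ug/mL. The expected step is a step that the limit leaves unreadable from compound 2 to compound 4, most likely again returning only a limit rather than a number.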

Compound 4, half-maximal cytotoxic concentration: > 100 ug/mL
Compound 4 ended at the assay's limit; the forecaster's own chance of this, stated with the estimate: 85%; middle value at least 1.6-fold (0.22 log units) away from the limit.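

In this assay compound 4 gives > 100 ug/mL, which is a limit and not a number. For the compounds shown here, compound 1, compound 2 and compound 3 also give only limits, and no step from any of them to compound 4 can be read. Still open, from the compounds shown here alone, is where the real half-maximal cytotoxic concentration of each compound lies, and whether changing the group on the carbonyl carbon shifts it at all.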